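Replacing pyridin-3-yl with 3,4,5-trimethoxyphenyl: compound 4 outlook

This account rests on a few compounds, and the source may have more. Where it says the series, first, only, none or still open, it means among the compounds named here.

Compound 1 `Cc1ccc(Cl)cc1Nc1nc(C(F)(F)F)ccc1C(=O)N/N=C/c1cccnc1` gives 12600 nM in a functional assay on NCI60 cells (Homo sapiens) for cytotoxicity, read by sulforhodamine B assay, with a stated time of 48 h; a higher number here means a weaker inhibitor of growth, a lower number a stronger inhibitor of growth.
Compound 2 `COc1ccc(Cl)cc1Nc1nc(C(F)(F)F)ccc1C(=O)N/N=C/c1ccc([N+](=O)[O-])cc1` gives 8710 nM in this assay.
Compound 3 `COc1ccc(Cl)cc1Nc1nc(C(F)(F)F)ccc1C(=O)N/N=C/c1cccnc1` gives 79400 nM in this assay.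

Compound 3 carries the highest number of the three: compound 1 stands nearer to it, by a 6.3-fold higher number from compound 1 to compound 3 (0.80 log units; beyond the scatter), and compound 2 furthest, by a 9.1-fold higher number from compound 2 to compound 3 (0.96 log units; beyond the scatter). The unmeasured compound 4 `COc1ccc(Cl)cc1Nc1nc(C(F)(F)F)ccc1C(=O)N/N=C/c1cc(OC)c(OC)c(OC)c1` differs from compound 3 in one place: 3,4,5-trimethoxyphenyl in place of pyridin-3-yl on a carbon with a double bond to nitrogen. Going by the values given here, the only measured step at this position is a 9.1-fold higher number from compound 2 to compound 3 (0.96 log units; beyond the scatter), where a carbon-only aromatic ring gave way to pyridin-3-yl and the number rose beyond the scatter. Among the compounds with values here, compound 4 reverses that direction, returning to a carbon-only ring, though no measured pair contains the 3,4,5-trimethoxyphenyl group, so the size of the effect is not fixed by the data. For compound 4 a lower number is expected, a step of about a 5.3-fold lower number from compound 3 to compound 4 (0.72 log units; beyond the scatter). Compound 4 is therefore estimated at 15000 nM in this assay, with a plausible range from 4000 nM to 60000 nM.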

Compound 4, concentration for total growth inhibition: 10500 nM
Compound 4: middle estimate off by 1.4-fold (0.15 log units), on the high side; the range from low to high includes it.
By their numbers in this assay, from the lowest: compounds 2, 4 and 1 (each within the scatter of the next); then compound 3.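

Going by these compounds alone, at the carbon with a double bond to nitrogen, a second carbon-only ring now stands against pyridin-3-yl in this assay and gives a 7.6-fold lower number from compound 3 to compound 4 (0.88 log units; beyond the scatter) so the earlier drop from 4-nitrophenyl is no longer a single pair. The two carbon-only rings are not told apart, with a 1.2-fold higher number from compound 2 to compound 4 (0.08 log units; within the scatter) even though 3,4,5-trimethoxyphenyl and 4-nitrophenyl are different groups. Among compounds 2, 3 and 4, the higher number goes only with pyridin-3-yl, and none of these three goes against that.

Nothing shown accounts for this difference. Still open, going by these compounds, is whether a carbon-only ring carrying an amine or a carboxylic acid in this place stays with compounds 2 and 4 or moves towards compound 3.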